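Swapping chloro for trifluoromethyl on compound 1

The compounds below may be only part of what the source reports. "The series", "measured", "known", "first", "only" and "open" are said of these compounds alone.

In a functional assay on the whole organism for positive allosteric modulation, with Mus musculus as the target (a higher number here means that more compound is needed for the effect, a lower number that less compound is needed), compound 1 (`CCC(=O)N(c1ccc(Cl)cc1)C1CCCC1N(C)C`) gives 3 mg/kg and sits close to compound 3 (`CCC(=O)N(c1ccc(Cl)c(C)c1)C1CCCC1N(C)C`), which gives 2 mg/kg as its dose. The measured step is a 1.5-fold lower number from compound 1 to compound 3 (0.18 log units; within the scatter) and comes from methyl in place of hydrogen on an aromatic carbon. Compound 2 (`CC(=O)N(c1ccccc1)C1CCCC1N(C)C`) stands further off at 7 mg/kg and needs clearly more compound than compound 1, but these two differ in more than one place, so their gap cannot be tied to a single change.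

Compound 4 (`CCC(=O)N(c1ccc(C(F)(F)F)cc1)C1CCCC1N(C)C`) keeps the core of compound 1 and carries trifluoromethyl in place of chloro on an aromatic carbon. Among the measured compounds shown here, no measured step swaps this group. For the measured compounds named here, the one single-place step available involves a different group and stayed small, which gives only weak guidance. In this assay the expected change is therefore no change at the digits printed from compound 1 to compound 4 (within the scatter) and no step beyond the scatter in either direction. Compound 4 is expected at 3 mg/kg and is estimated to fall from 1.3 mg/kg to 7 mg/kg as its range.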

Compound 4, dose for half-maximal effect: 10 mg/kg
Estimate against measurement, compound 4: 3.3-fold (0.52 log units) below, outside the stated range (above it).
By their numbers in this assay, from the lowest: compounds 3 and 1 (each within the scatter of the next); then compounds 2 and 4 (each within the scatter of the next).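

In this assay, the group on this aromatic carbon, para to a large group, clearly matters: trifluoromethyl in place of chloro gives a 3.3-fold higher number from compound 1 to compound 4 (0.52 log units; beyond the scatter) and so more compound is needed for the effect. The only earlier single-place step, a 1.5-fold lower number from compound 1 to compound 3 (0.18 log units; within the scatter) for methyl in place of hydrogen, stayed within the scatter, so this is the first step shown that goes beyond it. Nothing measured here accounts for why this swap raises the dose.

Still open, from the compounds shown here alone, is how other groups on this carbon would read, such as a nitrile, a methoxy group or a bromine atom. It is also unclear whether a step of this size would return on the core of compound 3, which carries the added methyl.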